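The source may hold more compounds than are shown below. What is called first, only, known or untested is meant among the compounds shown, and "the series" means these compounds.

Measured so far:
compound 1 `O=C1CCCN1c1cnc(NCc2c(F)ccc3c2CCO3)c2cn[nH]c(=O)c12` — 23 mL.min-1.g-1
compound 2 `C[C@H]1CC(=O)N(c2cnc(NCc3c(F)ccc4c3CCO4)n3cnnc23)C1` — a limit, < 3 mL.min-1.g-1

For the measured compounds named here, in an ADME assay on microsomes from liver (Homo sapiens) for metabolic stability, read by LC-MS, using NADPH, with stated times of 5 min and 30 min, tested at 1 uM (a lower number here means slower removal, a higher number faster removal of the compound), compound 1 gives 23 mL.min-1.g-1, the only plain number in the set. For compound 2 only a limit is reported, < 3 mL.min-1.g-1, so the limit of < 3 mL.min-1.g-1 in this assay, at which 1 of the 2 values shown sits, is all that is known of it. Compound 3 `Cc1nn(C)cc1-c1cnc(NCc2c(F)ccc3c2CCO3)c2cn[nH]c(=O)c12` is not yet measured. It differs from compound 1 by 1,3-dimethyl-1H-pyrazol-4-yl in place of 2-oxopyrrolidin-1-yl on an aromatic carbon. Going by the values given here, with no measured step to lean on, the step from compound 1 to compound 3 is expected to be small, upward if anything, and may not exceed the scatter: a 1.4-fold higher number from compound 1 to compound 3 (0.14 log units; within the scatter). Compound 3 is therefore estimated at 32 mL.min-1.g-1, between 10 mL.min-1.g-1 and 90 mL.min-1.g-1.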

Compound 3, intrinsic clearance in microsomes: 27 mL.min-1.g-1
Compound 3: middle estimate off by 1.2-fold (0.07 log units), on the high side; the measured number falls inside the stated range.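

In this assay, 1,3-dimethyl-1H-pyrazol-4-yl in place of 2-oxopyrrolidin-1-yl on this aromatic carbon gives a 1.2-fold higher number from compound 1 to compound 3 (0.07 log units; within the scatter) as its step. At this position, para to a large group, a five-membered aromatic ring with 2 hetero atoms and a five-membered non-aromatic ring with 1 hetero atom are therefore not told apart by this read-out. Nothing in hand accounts for the step.

As far as these compounds go, whether a basic amine or a carboxylic acid at this position would read the same remains open. So does whether an open chain, such as a longer alkyl ether, would behave like these two rings.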